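The source may hold more compounds than are shown below. What is called first, only, known or untested is meant among the compounds shown, and "the series" means these compounds.

Working notes on the series in a functional assay on the whole organism for inhibition, with Digitaria ciliaris as the target, with a stated time of 72 h, tested at 100 mg/L; a higher number here means more inhibition of growth at the concentration tested, a lower number less inhibition of growth.

Of the compounds shown here, three have numbers so far. Compound 1 `COc1cc(SC)nc(NC(=S)NC(=O)c2c(-c3ccc(Cl)cc3Cl)noc2C)n1` gives 55.6% in this assay. Compound 2 `COc1cc(Cl)nc2n/c(=N/C(=O)c3c(-c4ccc(Cl)cc4Cl)noc3C)sn12` gives 72.8%, and compound 3 `Cc1onc(-c2ccc(Cl)cc2Cl)c1C(=O)/N=c1/nc2nc(Cl)cc(C)n2s1` gives 68.1%. The only single-point step among these is a number 4.7 percentage points lower from compound 2 to compound 3 (within the scatter), a methyl in place of a methoxy on an aromatic carbon. Compound 1 stands lowest of the three numbers, beyond the scatter from compound 3, its nearest, and further still from compound 2.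

The next compound to be measured is compound 4 `Cc1cc(Cl)nc(NC(=S)NC(=O)c2c(-c3ccc(Cl)cc3Cl)noc2C)n1`. Its difference from compound 1:

4-chloro-6-methylpyrimidin-2-yl in place of 4-methoxy-6-(methylsulfanyl)pyrimidin-2-yl on an amide-type nitrogen

The change sits on the amide-type nitrogen whose other neighbour is the thiocarbonyl carbon; the core with the dichlorophenyl group is kept. Among the compounds with values here, no measured step covers the same exchange on the same core. The step from compound 2 to compound 3 also replaces a methoxy, there by a methyl, and stayed within the scatter; compounds 2 and 3 do not share the thiourea link of compound 1, so the bearing is loose. The expected step of a number 0.4 percentage points higher from compound 1 to compound 4 (within the scatter) is therefore small, with no clear direction, leaning to none beyond the scatter. Compound 4 is estimated at 56%, with a range from 40% to 72%.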

Compound 4, percent growth inhibition at one concentration: 44.2%
For compound 4 the middle estimate is 11.8 percentage points above the measured one; low and high end bracket the measured number.
By their numbers in this assay, from the lowest: compound 4; then compound 1; then compounds 3 and 2 (each within the scatter of the next).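

On the thiourea-linked compounds, the exchange of the pyrimidin-2-yl group on the amide-type nitrogen gives a step beyond the scatter in this assay: a number 11.4 percentage points lower from compound 1 to compound 4 (beyond the scatter). The earlier replacement of a methoxy by a methyl, a number 4.7 percentage points lower from compound 2 to compound 3 (within the scatter), did not show this, though it sits on compounds without the thiourea link and changes one group, whereas here the methoxy and the methylsulfanyl leave together. Nothing available on these compounds accounts for the lower number.

Which of the two groups that leave, or which of the methyl and chlorine that enter, carries the step remains open, since no compound shown separates them. Also open, from the compounds shown here alone, is how an amine or an ethoxy group in place of the methoxy would read on this thiourea-linked core.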